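Swapping the Aryl Group of Compound 1 for 3-Methylphenyl

This account rests on a few compounds, and the source may have more. Where it says the series, first, only, none or still open, it means among the compounds named here.

Compound 1 `COc1ccc(-c2cc3nccc(-c4cc(OC)c(OC)c(OC)c4)n3n2)cc1N` is tested in a functional assay on HCT-116 cells (Homo sapiens) for inhibition, read by CCK-8 assay, with a stated time of 48 h (on this read-out higher numbers stand for weaker inhibition and lower numbers for stronger inhibition), where it gives 251 nM, the highest of the three numbers measured. Compound 2 `COc1cc(-c2ccnc3cc(-c4ccc5cc[nH]c5c4)nn23)cc(OC)c1OC` gives 187 nM and compound 3 `COc1cc(-c2ccnc3cc(-c4ccc5c(ccn5C)c4)nn23)cc(OC)c1OC` gives 39 nM. Compound 4 `COc1cc(-c2ccnc3cc(-c4cccc(C)c4)nn23)cc(OC)c1OC` differs from compound 1 in one place: 3-methylphenyl in place of 3-amino-4-methoxyphenyl on an aromatic carbon. For the measured compounds named here, two measured steps bear on this change, since each also replaces the same group on the same aromatic carbon with a different aromatic group: a 1.3-fold lower number from compound 1 to compound 2 (0.13 log units; within the scatter) and a 6.4-fold lower number from compound 1 to compound 3 (0.81 log units; beyond the scatter). Both lowered the number, one within the scatter and one modestly beyond it, so a modest step in the same direction is expected for compound 4, or possibly none beyond the scatter, as a 1.7-fold lower number from compound 1 to compound 4 (0.22 log units; within the scatter). Compound 4 is therefore estimated at 150 nM, with a range from 50 nM to 500 nM.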

Compound 4, half-maximal inhibitory concentration: 6150 nM
Compound 4: middle estimate off by 41-fold (1.61 log units), on the low side, outside the stated range (above it).
By their numbers in this assay, from the lowest: compound 3; then compounds 2 and 1 (each within the scatter of the next); then compound 4.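

The change to 3-methylphenyl shows that a swap at this aromatic carbon can cost a great deal in this assay: it gives a 25-fold higher number from compound 1 to compound 4 (1.39 log units; beyond the scatter), and the steps from the two indolyl compounds are a 33-fold higher number from compound 2 to compound 4 (1.52 log units; beyond the scatter) and a 160-fold higher number from compound 3 to compound 4 (2.20 log units; beyond the scatter). Keeping a six-membered aromatic ring of carbon here is therefore not enough to hold the number low. Nothing available explains this rise.

The compounds shown leave open which part of 3-amino-4-methoxyphenyl matters, the amine or the methoxy. Going by these compounds, whether a 3-aminophenyl or a 4-methoxyphenyl group would keep the number low also remains open.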